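Three Para Substituents Set the Stage for a Fourth

The compounds below may be only part of what the source reports. "The series", "measured", "known", "first", "only" and "open" are said of these compounds alone.

Three compounds share one core: compound 1 `C[S+]([O-])c1ccc(CNC(=O)c2ccc(C(C)(C)C)cc2)cc1`, compound 2 `CSc1ccc(CNC(=O)c2ccc(C(C)(C)C)cc2)cc1` and compound 3 `CC(C)(C)c1ccc(C(=O)NCc2ccc(S(N)(=O)=O)cc2)cc1`. In an assay on HeLa cells with Bile acid receptor (Homo sapiens) as the target, read by a luciferase reporter, with a stated time of 24 h (on this read-out lower numbers stand for an effect already at smaller amounts and higher numbers for an effect only at larger amounts of compound), compound 1 gives 1300 nM, compound 2 gives 100 nM and compound 3 gives 1400 nM. Compound 3 therefore holds the highest of the three numbers, yet its gap to compound 1 is small, with a 1.1-fold higher number from compound 1 to compound 3 (0.03 log units; within the scatter), while a 14-fold higher number from compound 2 to compound 3 (1.15 log units; beyond the scatter) shows a large gap to compound 2. The same contrast appears in a 13-fold lower number from compound 1 to compound 2 (1.11 log units; beyond the scatter).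

Compound 4 `CC(C)(C)c1ccc(C(=O)NCc2ccc(CCC(=O)O)cc2)cc1` has not been measured. It differs from compound 3 in one place: 2-carboxyethyl in place of sulfamoyl on an aromatic carbon. Among the compounds with values here, none of the measured steps exchanges the sulfamoyl for a 2-carboxyethyl, so they give no direct guide. Within the data shown here, what they show is that the one group with no hydrogen-bond donor, methylsulfanyl in compound 2, stands far from the other two, whereas compound 1 and compound 3, each carrying a donor, sit within the scatter of one another. The entering group keeps one donor and one acceptor, so a step of modest size, if any, is expected, in the direction of a 1.6-fold lower number from compound 3 to compound 4 (0.19 log units; within the scatter). Compound 4 is expected to give 900 nM, with a range from 300 nM to 3000 nM.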

Compound 4, half-maximal effective concentration: 350 nM
Beside the measured number, compound 4's estimate is 2.6-fold (0.41 log units) above it; low and high end bracket the measured number.
By their numbers in this assay, from the lowest: compound 2; then compound 4; then compounds 1 and 3 (each within the scatter of the next).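

The earlier compounds shown here showed this position at only two levels, one low and one high, but in this assay the 2-carboxyethyl group sits at neither: it stands clear of the high pair (a 4.0-fold lower number from compound 3 to compound 4 (0.60 log units; beyond the scatter)) and (a 3.7-fold lower number from compound 1 to compound 4 (0.57 log units; beyond the scatter)), and also clear of the low level (a 3.5-fold higher number from compound 2 to compound 4 (0.54 log units; beyond the scatter)). Sulfamoyl and 2-carboxyethyl each count one hydrogen-bond donor, yet the numbers of compound 3 and compound 4 differ beyond the scatter, so the earlier split, with methylsulfanyl apart from the rest, can no longer be read simply as a donor being present or absent. Nothing measured alongside these numbers explains the size or direction of these steps.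

The compounds shown do not separate the contribution of the carboxylic acid at the end of the new group from that of the chain carrying it. A methyl ester or an amine on the same chain, or a shorter or longer chain ending in the carboxylic acid, would be needed to tell these two contributions apart.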